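From cyano to dimethylamino on the side chain

The compounds below may be only part of what the source reports. "The series", "measured", "known", "first", "only" and "open" are said of these compounds alone.

- Compound 1 `COC[C@@](O)([C@@H](Nc1cccc2nc(C)ccc12)c1ccc(OC)c(F)c1Cl)C(F)(F)F`: 0.2 nM
- Compound 2 `COc1ccc([C@H](Nc2cccc3nc(C)ccc23)[C@](O)(CC#N)C(F)(F)F)c(Cl)c1F`: 1.26 nM

Among the compounds with values here, in a functional assay on THP-1 cells (Homo sapiens) (a lower number here means a stronger inhibitor, a higher number a weaker inhibitor), compound 2 gives 1.26 nM, the higher of the two numbers so far. Compound 3 `COc1ccc([C@H](Nc2cccc3nc(C)ccc23)[C@](O)(CN(C)C)C(F)(F)F)c(Cl)c1F` keeps the rest of compound 2 and changes one group: dimethylamino in place of cyano on a saturated chain carbon, two bonds along the chain from an oxygen on a saturated carbon. This places dimethylamino in place of cyano on a saturated chain carbon, two bonds along the chain from an oxygen on a saturated carbon.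

Within the data shown here, only one measured step bears on this place, and it is modest: a 6.3-fold higher number from compound 1 to compound 2 (0.80 log units; beyond the scatter). It shows that a change here can move the number, but dimethylamino itself has not been measured, so the data give no direction. The expected result is therefore no clear shift, and the estimated step is a 1.2-fold higher number from compound 2 to compound 3 (0.08 log units; within the scatter). For compound 3 the estimated value is 1.5 nM, with an expected range of 0.3 nM to 8 nM.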

Compound 3, half-maximal inhibitory concentration in the THP-1 assay: 5.01 nM
Estimate against measurement, compound 3: 3.3-fold (0.52 log units) below, within the range that was stated.
By their numbers in the THP-1 assay, from the lowest: compound 1; then compound 2; then compound 3.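

In the THP-1 assay this position proves sensitive a second time: the new group gives a 4.0-fold higher number from compound 2 to compound 3 (0.60 log units; beyond the scatter), and set against the methoxy group, it gives a 25-fold higher number from compound 1 to compound 3 (1.40 log units; beyond the scatter). Of the three groups shown on this saturated chain carbon, methoxy therefore gives the strongest inhibitor and dimethylamino the weakest. In a physicochemical assay for lipophilicity (on this read-out higher numbers stand for higher lipophilicity and lower numbers for lower lipophilicity), compound 2 gives 3.4 and compound 3 gives 5.3. The swap from cyano to dimethylamino also raises lipophilicity, so in this pair higher lipophilicity comes with weaker inhibition, not stronger: the measured partition coefficient of compound 2, 3.4, and of compound 3, 5.3, a number 1.90 log units higher (beyond the scatter)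

A single pair cannot separate the part played by lipophilicity from that of the size or other features of the entering group. As far as these compounds go, whether a ring-bound amine such as morpholine, or a simple hydroxyl, would keep the low numbers of compound 1 on this carbon remains open.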